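Acetyl in Place of Hydrogen on the Ring Amine

This account rests on a few compounds, and the source may have more. Where it says the series, first, only, none or still open, it means among the compounds named here.

Compound 3 `C(=C/c1ccccc1OCCCCN1CCNCC1)\c1ccccc1` gives 0% in a functional assay on the whole organism with Mus musculus as the target, in the maximal electroshock model, at a dose of 50 mg/kg by the oral route (a lower number here means less inhibition, a higher number more inhibition at the dose given (going by the name of the read-out)), level with compound 2 `OC1CCN(CCCCOc2ccccc2/C=C/c2ccccc2)CC1` at 0%, the two together the lowest of the three numbers, while compound 1 `CN(C)CCCOc1ccccc1/C=C/c1ccccc1` gives 14.2%. The steps of a number 14.2 percentage points lower from compound 1 to compound 2 (beyond the scatter) and a number 14.2 percentage points lower from compound 1 to compound 3 (beyond the scatter) both lie beyond the scatter, whereas no change at the digits printed from compound 2 to compound 3 (within the scatter). Compound 4 `CC(=O)N1CCN(CCCCOc2ccccc2/C=C/c2ccccc2)CC1` differs from compound 3 by acetyl in place of hydrogen on an amine nitrogen in a ring. Among the compounds with values here, none of the measured steps touches this ring amine nitrogen itself; the nearest comparison, piperazin-1-yl in place of 4-hydroxypiperidin-1-yl, left the number where it was. Compound 4 is therefore expected to show a number 3 percentage points higher from compound 3 to compound 4 (within the scatter). For compound 4 the estimated value is 3%, with a range from 0% to 15%.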

Compound 4, a percentage reported as inhibition, in the whole organism at one dose (the size of the read-out at that dose, not a potency): 0%
Beside the measured number, compound 4's estimate is 3 percentage points above it, within the range that was stated.
By their numbers in this assay, from the lowest: compounds 2, 3 and 4 (each within the scatter of the next); then compound 1.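

In this assay, the ring amine nitrogen now has a step of its own: acetyl in place of hydrogen there gives no change at the digits printed from compound 3 to compound 4 (within the scatter). The 4-acetylpiperazin-1-yl group in place of 4-hydroxypiperidin-1-yl likewise gives no change at the digits printed from compound 2 to compound 4 (within the scatter). With compound 3 at 0%, acetyl on this nitrogen brought no measurable inhibition at the dose given, and the reading cannot show whether it would lower inhibition from a higher starting point. Going by these compounds, whether a methyl or benzyl group on this nitrogen, or a shorter chain to the ring, would give a number above zero remains open. Nothing available explains these readings.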